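The source may report more compounds than this note shows. Statements on the series, on what has been measured and on what is new or still open speak of the compounds shown alone.

Compound 1 `NC1CCC(Nc2nc(NCc3ccc(-c4ccccc4)cc3)c3ncn(C4CCCC4)c3n2)CC1` is one of three close relatives tested in a functional assay on HCT-116 cells (Homo sapiens) for inhibition, with a stated time of 72 h (on this read-out lower numbers stand for stronger inhibition and higher numbers for weaker inhibition), where compound 1 gives 745 nM. Compound 2 `COc1ccccc1-c1ccc(CNc2nc(NC3CCC(N)CC3)nc3c2ncn3C2CCCC2)cc1` gives 430 nM and compound 3 `NC1CCC(Nc2nc(NCc3ccc(-c4cccc(F)c4)cc3)c3ncn(C4CCCC4)c3n2)CC1` gives 551 nM. Compound 1 shows the highest of the three numbers, but both neighbours lie close: a 1.7-fold lower number from compound 1 to compound 2 (0.24 log units; within the scatter), and a 1.4-fold lower number from compound 1 to compound 3 (0.13 log units; within the scatter). Between the other two, a 1.3-fold higher number from compound 2 to compound 3 (0.11 log units; within the scatter). Compound 4 `NC1CCC(Nc2nc(NCc3ccc(-c4ccco4)cc3)c3ncn(C4CCCC4)c3n2)CC1` has not yet been measured. It differs from compound 1 in one place: furan-2-yl in place of phenyl on an aromatic carbon. The phenyl that leaves is a six-membered aromatic ring of carbon only; the furan-2-yl that enters is a five-membered aromatic ring with one hetero atom and brings one hydrogen-bond acceptor, sitting para to a large group. The measured steps all alter this same outer ring, and each stayed within the usual scatter, so a similarly small step is expected in this assay, though none of them replaces the whole ring. Compound 4 is therefore estimated at 650 nM, with a range from 300 nM to 1500 nM. That estimate amounts to a step of a 1.1-fold lower number from compound 1 to compound 4 (0.06 log units; within the scatter), which is expected to be no larger than the scatter.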

Compound 4, half-maximal inhibitory concentration: 129 nM
Beside the measured number, compound 4's estimate is 5.0-fold (0.70 log units) above it; the measured number lies below the stated range.
By their numbers in this assay, from the lowest: compound 4; then compounds 2, 3 and 1 (each within the scatter of the next).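

In this assay, this place on the outer ring proved far more sensitive to exchanging the whole ring than to adding a group to it (a 5.8-fold lower number from compound 1 to compound 4 (0.76 log units; beyond the scatter)), whereas the fluoro and methoxy changes on the phenyl stayed within the scatter. The furan-2-yl also stands apart from both substituted phenyl rings (a 4.3-fold lower number from compound 3 to compound 4 (0.63 log units; beyond the scatter); a 3.3-fold lower number from compound 2 to compound 4 (0.52 log units; beyond the scatter)), so compound 4 is the only one of the four whose number clearly separates from the others. Nothing available here explains why this five-membered ring gives the lower number.

The compounds shown cannot tell whether the oxygen or the smaller ring matters more, a question that a thiophen-2-yl, with sulfur in place of oxygen, would help to answer. They also leave open whether the oxygen's location counts, as a furan-3-yl would show, and whether a pyridin-3-yl, a six-membered ring containing nitrogen, would give a similar gain.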